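From 3-chlorophenyl to 2-chlorophenyl on a shared core

The compounds below may be only part of what the source reports. "The series", "measured", "known", "first", "only" and "open" are said of these compounds alone.

In a functional assay on PC-3 cells (Homo sapiens) for inhibition, read by MTT assay, with a stated time of 48 h, tested at 10 uM (a higher number here means more inhibition of growth at the concentration tested, a lower number less inhibition of growth), compound 1 (`Cc1cc(=O)c2c(O)cc(OCc3ccc(Br)cc3)c([C@H]3CCN(C)C[C@H]3O)c2o1`) gives 17% and compound 2 (`Cc1cc(=O)c2c(O)c(CN3CCCCC3)c(O)c([C@H]3CCN(C)C[C@H]3O)c2o1`) gives 14% at the tested concentration. Compound 3 (`CN1CC[C@H](c2c(O)cc(O)c3c(=O)cc(/C=C/c4cccc(Cl)c4)oc23)[C@H](O)C1`) gives 53% as the highest of the three numbers, beyond the scatter of both others. Compound 4 (`CN1CC[C@H](c2c(O)cc(O)c3c(=O)cc(/C=C/c4ccccc4Cl)oc23)[C@H](O)C1`) has the same atoms joined differently, with 2-chlorophenyl in place of 3-chlorophenyl on a double-bonded chain carbon bound to a double-bonded chain carbon. Among the measured compounds shown here, no measured pair shows such a change, so no step beyond the scatter is expected in this assay for this swap. The expected outcome is a number 5 percentage points lower from compound 3 to compound 4 (within the scatter) within that scatter. For compound 4 the estimate is 48% with 28% to 66% as its expected range.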

Compound 4, percent growth inhibition at one concentration: 22%
The estimate for compound 4 lay 26 percentage points above the measured number; measured number outside the range, below it.
By their numbers in this assay, from the lowest: compounds 2, 1 and 4 (each within the scatter of the next); then compound 3.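

In this assay, 2-chlorophenyl in place of 3-chlorophenyl on a double-bonded chain carbon bound to a double-bonded chain carbon gives a number 31 percentage points lower from compound 3 to compound 4 (beyond the scatter) as a large step. The earlier compounds shown here offered no pair differing in one place, and this pair shows that, with the same atoms on the shared core, where the chlorine sits on the phenyl ring alone separates the two numbers. No measurement shown here accounts for the step. The compounds shown leave open whether a phenyl ring without chlorine, or one carrying a nitrile instead, would stand nearer compound 3 or compound 4 in this assay.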